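From thiophen-2-yl to 4-ethoxyphenyl on the shared core

The source may hold more compounds than are shown below. What is called first, only, known or untested is meant among the compounds shown, and "the series" means these compounds.

In a functional assay on MOLT-4 cells (Homo sapiens) for antiproliferative activity (on this read-out higher numbers stand for weaker inhibition and lower numbers for stronger inhibition), compound 3 `COc1cc(C(=O)c2sc(-c3cccs3)cc2N)cc(OC)c1OC` gives 8.9 nM and compound 2 `COc1cc(C(=O)c2sc(-c3ccc(F)cc3)cc2N)cc(OC)c1OC` gives 12 nM, a pair set apart only by a 1.3-fold lower number from compound 2 to compound 3 (0.13 log units; within the scatter). Compound 1 `COc1cc(C(=O)c2sc(-c3ccc(Br)cc3)cc2N)cc(OC)c1OC` gives 92 nM, and compound 3 lies well under it, with a 10-fold lower number from compound 1 to compound 3 (1.01 log units; beyond the scatter). Compound 4 `CCOc1ccc(-c2cc(N)c(C(=O)c3cc(OC)c(OC)c(OC)c3)s2)cc1` carries 4-ethoxyphenyl in place of thiophen-2-yl on an aromatic carbon. Like compound 1 and compound 2, it bears a substituted phenyl, and that substituent mattered there: fluoro for bromo gave a 7.7-fold lower number from compound 1 to compound 2 (0.88 log units; beyond the scatter). Ethoxy itself is untested, so compound 4 could fall anywhere across that span. A modest rise is expected, a 2.8-fold higher number from compound 3 to compound 4 (0.45 log units; beyond the scatter). Compound 4 is estimated at 25 nM, within an expected range of 6 nM to 100 nM.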

Compound 4, half-maximal inhibitory concentration: 240 nM
Compound 4: the middle estimate sits 9.6-fold (0.98 log units) below what was measured; the whole stated range lies below it.
By their numbers in this assay, from the lowest: compounds 3 and 2 (each within the scatter of the next); then compound 1; then compound 4.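

In this assay, 4-ethoxyphenyl on this aromatic carbon, next to the ring sulfur, gives large losses against the two lowest compounds (a 27-fold higher number from compound 3 to compound 4 (1.43 log units; beyond the scatter); a 20-fold higher number from compound 2 to compound 4 (1.30 log units; beyond the scatter)). Ethoxy also gives a higher number than bromo (a 2.6-fold higher number from compound 1 to compound 4 (0.42 log units; beyond the scatter)), so with the phenyl kept, changing its substituent alone can produce a large step. Larger groups on the phenyl are therefore not shown to be tolerated here, with ethoxy giving the highest number of the four.

No evidence available here explains this result. As far as these compounds go, whether methoxy, hydroxyl or an amine on the phenyl would restore the lower numbers remains open.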